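This account rests on a few compounds, and the source may have more. Where it says the series, first, only, none or still open, it means among the compounds named here.

Working notes on the series. In an ADME assay on microsomes from liver (Mus musculus) for metabolic stability, read by LC-MS, using NADPH, with a stated time of 10 min, tested at 10 uM (on this read-out higher numbers stand for a longer-lived compound and lower numbers for a shorter-lived compound), compound 2 `Nc1ncnc2c1c(Oc1cc(C(F)(F)F)ccn1)nn2[C@H]1CC[C@@H](N)CC1` gives 0.917 h, the highest of the three numbers in hand. Compound 1 `Nc1ncnc2c1c(Oc1cccc(C(F)(F)F)c1)nn2[C@H]1C[C@H](O)C1` gives 0.367 h in this assay, a lower number than compound 2, and compound 3 `Cc1cccc(Oc2nn(C(C)(C)C)c3ncnc(N)c23)c1` gives 0.0717 h, the lowest of the three; both gaps to compound 2 lie beyond the usual scatter. No two of the measured compounds differ in a single place, so no single-point step can be read off.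

Compound 4 `Nc1ncnc2c1c(Oc1cc(C(F)(F)F)ccn1)nn2[C@@H]1CCCC[C@H]1O` has not yet been measured. It departs from compound 2 by 2-hydroxycyclohexyl in place of 4-aminocyclohexyl on an aromatic nitrogen. Going by the values given here, the only measured compound whose ring on that aromatic nitrogen also carries a hydroxy group is compound 1, which gives 0.367 h in this assay, a smaller number than compound 2, but its ring size and the aryl ether differ as well, so the comparison is loose. The expected step of a 1.7-fold lower number from compound 2 to compound 4 (0.22 log units; within the scatter) is a modest move downward, at or within the scatter, and compound 4 is estimated to give 0.55 h in this assay, with a range from 0.22 h to 1.3 h.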

Compound 4, half-life: 1.1 h
Beside the measured number, compound 4's estimate is 2.0-fold (0.30 log units) below it, within the range that was stated.
By their numbers in this assay, from the lowest: compound 3; then compound 1; then compounds 2 and 4 (each within the scatter of the next).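

Going by these compounds alone, the step of a 1.2-fold higher number from compound 2 to compound 4 (0.08 log units; within the scatter) is the first single-place comparison, and it comes from 2-hydroxycyclohexyl in place of 4-aminocyclohexyl on an aromatic nitrogen, read in this assay. With the shared core and the aryl ether held fixed, this position accepts a hydroxy-bearing six-membered carbon ring in place of an amino-bearing one with no difference that can be told from the scatter, so the 4-aminocyclohexyl group is not needed here for a half-life of this size. Nothing on hand speaks to why the two groups read alike.

Still open, as far as these compounds go, is whether a carboxylic acid or a longer chain on the same aromatic nitrogen would read alike. Also open, from the compounds shown here alone, is whether the exchange holds with the other aryl ethers of compound 1 and compound 3, or with the other stereocentres of the 2-hydroxycyclohexyl group.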